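This account rests on a few compounds, and the source may have more. Where it says the series, first, only, none or still open, it means among the compounds named here.

Compound 1 `O=C(CCc1cccc2c1B(O)OC2)Nc1ccc(F)cc1`: 650 nM
Compound 2 `O=C(CCc1cccc2c1B(O)OC2)Nc1ccc(I)cc1`: 50000 nM

In a functional assay on HCT-116 cells (Homo sapiens) for antiproliferative activity, read by MTT assay, with a stated time of 72 h (on this read-out lower numbers stand for stronger inhibition and higher numbers for weaker inhibition), compound 2 has the higher of the two numbers, at 50000 nM. Compound 3 `C#Cc1ccc(NC(=O)CCc2cccc3c2B(O)OC3)cc1` differs from it by ethynyl in place of iodo on an aromatic carbon, with ethynyl in place of iodo on an aromatic carbon. Within the data shown here, one measured step bears on this place: a 77-fold higher number from compound 1 to compound 2 (1.89 log units; beyond the scatter), which is large. Among the measured compounds shown here, no ethynyl compound has been measured, so the size remains uncertain, but a partial return towards compound 1 seems likely. The expected change is a 10-fold lower number from compound 2 to compound 3 (1.00 log units; beyond the scatter), a move to a lower number in this assay. The estimated value for compound 3 is 5000 nM, within a range of 700 nM to 40000 nM.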

Compound 3, half-maximal inhibitory concentration: 45000 nM
For compound 3 the middle estimate is 9.0-fold (0.95 log units) below the measured one; measured number outside the range, above it.
By their numbers in this assay, from the lowest: compound 1; then compounds 3 and 2 (each within the scatter of the next).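

In this assay, ethynyl in place of iodo gives a 1.1-fold lower number from compound 2 to compound 3 (0.05 log units; within the scatter), so at this place on the ring the two groups cannot be told apart. Ethynyl in place of fluoro gives a 69-fold higher number from compound 1 to compound 3 (1.84 log units; beyond the scatter), so the large step seen with iodo is not peculiar to iodo, and among these three compounds only compound 1 stands apart. No supporting data bear on why the fluoro compound differs from the other two.

Going by these compounds, whether chloro or methoxy at this place would fall with compound 1 or with compounds 2 and 3 stays open. The same question holds for an amine.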